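Pyridinyl isomer swap on the fused bicyclic core

The source may hold more compounds than are shown below. What is called first, only, known or untested is meant among the compounds shown, and "the series" means these compounds.

Compound 1 `Cc1cn2c(/C=N/NC(=N)N)c(-c3cccnc3)nc2s1` gives 5620 nM in a functional assay on colon cells (Homo sapiens) for antiproliferative activity; on this read-out higher numbers stand for weaker inhibition of growth and lower numbers for stronger inhibition of growth. Compound 2 `N=C(N)N/N=C/c1c(-c2cc([N+](=O)[O-])c(Cl)cc2Cl)nc2sc(Cl)cn12` gives 5750 nM in this assay, and compound 3 `N=C(N)N/N=C/c1c(-c2cccnc2)nc2sc(Cl)cn12` gives 8510 nM; all three numbers lie within the usual scatter of one another, so compound 1 cannot be set apart from the other two on these data. Among the measured compounds shown here, the only single-point step measured so far, a 1.5-fold higher number from compound 1 to compound 3 (0.18 log units; within the scatter), concerns a different position and did not move the number beyond the scatter.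

Compound 4 `Cc1cn2c(/C=N/NC(=N)N)c(-c3ccccn3)nc2s1` differs from compound 1 by pyridin-2-yl in place of pyridin-3-yl on an aromatic carbon. No measured pair in the set carries the same change, so no step bears on it directly; the series has so far shown no change that moves this assay beyond the scatter. The step from compound 1 to compound 4 is therefore expected to be a 1.0-fold lower number from compound 1 to compound 4 (0.00 log units; within the scatter), with no movement beyond the scatter in either direction. For compound 4 the estimate is 5600 nM in this assay, within a range from 2000 nM to 16000 nM.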

Compound 4, concentration for 50% growth inhibition: 8130 nM
The estimate for compound 4 lay 1.5-fold (0.16 log units) below the measured number; the range from low to high includes it.
By their numbers in this assay, from the lowest: compounds 1, 2, 4 and 3 (each within the scatter of the next).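

In this assay the swap at this aromatic carbon gives a 1.4-fold higher number from compound 1 to compound 4 (0.16 log units; within the scatter) and so stays inside the scatter. Among the compounds shown here, this is the first read on the group at this place with the rest of compound 1 held constant, and on these data pyridin-2-yl and pyridin-3-yl cannot be told apart in growth inhibition. No supporting measurement bears on this result.

Open, on these data alone, is whether any group at this aromatic carbon moves the number beyond the scatter, since the two pyridinyl isomers compared here keep the same atoms and differ only in how they are joined. Pyridin-4-yl would complete the isomer set, and a phenyl ring carrying an amine or a carboxylic acid would test a wider change at the same place on the core of compound 1.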